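Aryl swap on the sulfonamide of a triazole URAT1 inhibitor

The compounds below may be only part of what the source reports. "The series", "measured", "known", "first", "only" and "open" are said of these compounds alone.

Three compounds share a core in which a brominated triazole carries a bromonaphthylmethyl group and a thioether-linked side chain. Compound 1 `Oc1c(Br)cc(CSc2nnc(Br)n2Cc2ccc(Br)c3ccccc23)cc1Br` ends in a dibromohydroxyphenyl group; in an assay on HEK293 cells for inhibition of solute carrier family 22 member 12 (Homo sapiens) (on this read-out lower numbers stand for stronger inhibition and higher numbers for weaker inhibition), compound 1 gives 119000 nM. Compound 2 `O=C(CSc1nnc(Br)n1Cc1ccc(Br)c2ccccc12)NO` carries a hydroxycarbamoyl instead, and compound 2 gives 640 nM, so that a 190-fold lower number from compound 1 to compound 2 (2.27 log units; beyond the scatter). Compound 3 `O=S(=O)(CSc1nnc(Br)n1Cc1ccc(Br)c2ccccc12)Nc1cncc(C(F)(F)F)c1` bears a sulfonamide to a trifluoromethylpyridinyl group; compound 3 gives 6380 nM, the second highest number of the three, below the number of compound 1 and above that of compound 2.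

Compound 4 `O=S(=O)(CSc1nnc(Br)n1Cc1ccc(Br)c2ccccc12)Nc1ccc(Cl)nc1Cl` differs from compound 3 by 2,6-dichloropyridin-3-yl in place of 5-(trifluoromethyl)pyridin-3-yl on a sulfonamide nitrogen. Going by the values given here, no measured step touches this position: the only step on record, from compound 1 to compound 2, concerns the far end of the side chain and a wholly different group. With nothing to lean on, the expectation is a step no larger than the scatter, a 1.1-fold lower number from compound 3 to compound 4 (0.03 log units; within the scatter). Compound 4 is therefore estimated at 6000 nM, with a range from 1500 nM to 25000 nM.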

Compound 4, half-maximal inhibitory concentration: 1660 nM
For compound 4 the middle estimate is 3.6-fold (0.56 log units) above the measured one, and the stated range covers the measured number.
By their numbers in this assay, from the lowest: compound 2; then compound 4; then compound 3; then compound 1.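

In this assay, exchanging 5-(trifluoromethyl)pyridin-3-yl for 2,6-dichloropyridin-3-yl on a sulfonamide nitrogen gives a 3.8-fold lower number from compound 3 to compound 4 (0.58 log units; beyond the scatter), showing that the number responds to the aryl group at this position, even with the sulfonamide link unchanged. Both groups are six-membered aromatic rings with one hetero atom and the same counts of donors and acceptors, but the entering group has fewer heavy atoms and carries chlorine rather than fluorine, and this single exchange cannot separate those differences. Nothing measured here explains the step.

As far as these compounds go, it remains open whether a plain phenyl group or a pyridine ring bearing a single chlorine on the sulfonamide nitrogen would fall nearer compound 3 or compound 4. Also unresolved is how a carboxylic acid in place of the sulfonamide would compare.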